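A few compounds are considered here, and "the series" means these few. Any claim that something is new, unique, unknown or untested is made for them only; others in the source may bear on it.

Measured in a functional assay on MGC-803 cells (Homo sapiens) for inhibition, read by MTT assay, with a stated time of 48 h (on this read-out lower numbers stand for stronger inhibition and higher numbers for weaker inhibition), as follows:
- Compound 1 `COc1ccc(CNc2cc(OC)c(OC)c(OC)c2)cc1[N+](=O)[O-]` gives 19400 nM
- Compound 2 `COc1ccc(CN(C(C)=O)c2cc(OC)c(OC)c(OC)c2)cc1O` gives 79 nM
- Compound 3 `C/C=C/C(=O)N(Cc1cc(OC)c(OC)c(OC)c1)c1ccc(OC)c(O)c1` gives 6150 nM

Compound 2 stands lowest of the three, and its gaps to compound 3 and compound 1 both lie beyond the scatter. Compound 4 `C/C=C/C=C/C(=O)N(Cc1ccc(OC)c(O)c1)c1cc(OC)c(OC)c(OC)c1` departs from compound 2 in one place, penta-1,3-dien-1-yl in place of methyl on a carbonyl carbon with penta-1,3-dien-1-yl in place of methyl on a carbonyl carbon. Going by the values given here, no measured pair differs by this change alone, so the guide is thin. The higher number of compound 3 at 6150 nM suggests that the low value of compound 2 may not survive it. In this assay the expected step is a 19-fold higher number from compound 2 to compound 4 (1.28 log units; beyond the scatter) toward higher numbers, beyond the scatter. Compound 4 is estimated at 1500 nM with an expected range from 250 nM to 10000 nM for the coming measurement.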

Compound 4, half-maximal inhibitory concentration: 140 nM
Compound 4: middle estimate off by 11-fold (1.03 log units), on the high side, and the stated range ends above it.
By their numbers in this assay, from the lowest: compounds 2 and 4 (each within the scatter of the next); then compound 3; then compound 1.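

Within this assay the penta-1,3-dien-1-yl chain, on a carbonyl carbon whose other neighbour is an amide-type nitrogen, replaces methyl with a 1.8-fold higher number from compound 2 to compound 4 (0.25 log units; within the scatter) and so leaves the number within the scatter. Going by these compounds alone, this position therefore accepts five carbons in place of one, which no earlier single-place pair could show. No supporting measurement here bears on why.

The compounds shown do not separate the chain's length from its double bonds, which a saturated pentyl chain could address. From the compounds shown here alone, whether an amine or a carboxylic acid on this chain would be accepted also stays open.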